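Removing the fluorines from compound 2

A few compounds are considered here, and "the series" means these few. Any claim that something is new, unique, unknown or untested is made for them only; others in the source may bear on it.

Measured so far in an in vitro functional assay on cells for agonist activity at Bombesin receptor subtype-3 (Homo sapiens), read by luminescence and calcium flux; a higher number here means that more compound is needed for the effect, a lower number that less compound is needed:
compound 1 `CC(C)(C)CCc1cnc(CCc2ccc(-c3ccccc3C(=O)O)cc2)[nH]1` gives 39 nM.
compound 2 `O=C(O)c1ccccc1-c1ccc(CCc2ncc(Cc3cccc(F)c3F)[nH]2)cc1` gives 87 nM.

Compound 2 stands highest of the two numbers; its nearest neighbour is compound 1, and the step of a 2.2-fold higher number from compound 1 to compound 2 (0.35 log units; beyond the scatter) is modest but beyond the scatter.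

Compound 3 `O=C(O)c1ccccc1-c1ccc(CCc2ncc(Cc3ccccc3)[nH]2)cc1` is not yet measured. It differs from compound 2 by phenyl in place of 2,3-difluorophenyl on a saturated chain carbon bound to an aromatic carbon. No measured step changes a substituent on the aromatic ring of this benzyl group; the only step shown, a 2.2-fold higher number from compound 1 to compound 2 (0.35 log units; beyond the scatter), swaps the whole group and so bears only loosely on the move to compound 3. With two measured compounds that are themselves separated by a modest step, the expectation for compound 3 is a number close to that of compound 2, with no step beyond the scatter, expressed as a 1.1-fold lower number from compound 2 to compound 3 (0.04 log units; within the scatter). The estimate for compound 3 in this assay is 80 nM, with a range from 30 nM to 220 nM.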

Compound 3, half-maximal effective concentration: 205 nM
For compound 3 the middle estimate is 2.6-fold (0.41 log units) below the measured one; the measured number falls inside the stated range.
By their numbers in this assay, from the lowest: compound 1; then compound 2; then compound 3.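

In this assay, going from 2,3-difluorobenzyl to benzyl gives a 2.4-fold higher number from compound 2 to compound 3 (0.37 log units; beyond the scatter), so substitution on this aromatic ring alone moves the number, which the earlier swap of the whole group could not show. Against compound 1, which carries neopentyl at this place, the phenyl group gives a 5.3-fold higher number from compound 1 to compound 3 (0.72 log units; beyond the scatter), so the three groups run neopentyl, 2,3-difluorophenyl, phenyl from the lowest number to the highest, with every step beyond the scatter. No supporting data bear on the reason for this order.

As far as these compounds go, whether a single fluorine carries the difference, or both are needed, remains open. So does the outcome for other substituents on this ring, such as a chlorine atom or a methoxy group, and for a longer chain linking the ring to the core.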